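This account rests on a few compounds, and the source may have more. Where it says the series, first, only, none or still open, it means among the compounds named here.

Measured compounds:
- compound 1, `COc1cc(-c2cc(/C=C/C(=O)c3ccc(N)cc3)[nH]n2)cc(OC)c1OC`, in a functional assay on RPMI-8226 cells (Homo sapiens) for cytotoxicity, read by sulforhodamine B assay, with a stated time of 48 h, tested at 100 uM (on this read-out higher numbers stand for a weaker effect at the one concentration tested and lower numbers for a stronger effect), compound 1 gives -40%
- compound 2, `COc1ccc(C(=O)/C=C/c2cc(-c3cc(OC)c(OC)c(OC)c3)n[nH]2)cc1`, in this assay compound 2 gives -34%

Compound 2 holds the higher of the two numbers, but the step between them is only a number 6 percentage points higher from compound 1 to compound 2 (within the scatter), so the two stand level within the scatter. Going by the values given here, the single measured step, methoxy in place of amino on an aromatic carbon, thus shows no movement that can be read.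

Compound 3, `COc1cc(-c2cc(/C=C/C(=O)c3ccc(F)c(F)c3)[nH]n2)cc(OC)c1OC`, is not yet measured. It differs from compound 2 by 3,4-difluorophenyl in place of 4-methoxyphenyl on a carbonyl carbon. Among the compounds with values here, no measured step touches this position with this kind of change; the only comparison available, from compound 1 to compound 2, varies a substituent on the same aromatic ring and stays flat. No step beyond the scatter is therefore expected in this assay for compound 3, and the estimated step is a number 1 percentage points lower from compound 2 to compound 3 (within the scatter). The value expected for compound 3 is -35%, with a range from -60% to -5%.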

Compound 3, a percentage reported as activity, at one concentration (the size of the read-out at that concentration, not a potency): -36%
The estimate for compound 3 lay 1 percentage points above the measured number, within the range that was stated.
By their numbers in this assay, from the lowest: compounds 1, 3 and 2 (each within the scatter of the next).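

On a carbonyl carbon, 3,4-difluorophenyl in place of 4-methoxyphenyl shows no readable movement in this assay (a number 2 percentage points lower from compound 2 to compound 3 (within the scatter)). The same holds for 3,4-difluorophenyl in place of 4-aminophenyl (a number 4 percentage points higher from compound 1 to compound 3 (within the scatter)). The position therefore accepts a fluorinated ring as well as the methoxy- and amino-bearing rings without a readable change in this assay, so all three aryl groups stand level, and no information on why this is so bears on the result.

The compounds shown leave open whether a carboxylic acid, a morpholine or a longer alkyl chain on this ring would give a step beyond the scatter. They also leave open whether changes elsewhere on the shared core would move the read-out, since all three compounds keep that core unchanged.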